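The source may report more compounds than this note shows. Statements on the series, on what has been measured and on what is new or still open speak of the compounds shown alone.

Compound 1, with the structure `CN1C/C(=C\c2ccccc2)C(=O)[C@]2(C1)[C@@H](c1ccccc1)CN(C)[C@@]21C(=O)Nc2ccccc21`, was tested in a functional assay on the whole organism (strain Wister albino) for inhibition, with Rattus norvegicus as the target, read by paw edema, with stated times of 1 h and 24 h, at a dose of 50 mg/kg by the intraperitoneal route (on this read-out lower numbers stand for less inhibition and higher numbers for more inhibition at the one dose given (going by the name of the read-out)), where compound 1 gives 65.1%. Compound 2, with the structure `CN1C/C(=C\c2ccccc2)C(=O)[C@]2(C1)[C@@H](c1ccccc1)CN(C)[C@@]21C(=O)N(C)c2ccccc21`, carries one change relative to compound 1, namely (methyl in place of hydrogen on an amide-type nitrogen in a ring). In this assay compound 2 gives 26.5%, so that this single change produced a step of a number 38.6 percentage points lower from compound 1 to compound 2 (beyond the scatter).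

Compound 3, with the structure `CN1C/C(=C\c2ccc(-c3cccs3)cc2)C(=O)[C@]2(C1)[C@@H](c1ccc(-c3cccs3)cc1)CN(C)[C@@]21C(=O)Nc2ccccc21`, rests on a different core from compound 1; the difference between the two cores is not broken down here. In this assay compound 3 gives 79.8%, which stands above the reading of compound 1 and well above that of compound 2.

Compound 4, with the structure `CN1C/C(=C\c2ccc(-c3cccs3)cc2)C(=O)[C@]2(C1)[C@@H](c1ccc(-c3cccs3)cc1)CN(C)[C@@]21C(=O)N(C)c2ccccc21`, has not yet been measured. Among the measured compounds shown here, it differs from compound 3 by methyl in place of hydrogen on an amide-type nitrogen in a ring, the same change as the one that turned compound 1 into compound 2, at the same kind of place. Because the earlier change gave a step of a number 38.6 percentage points lower from compound 1 to compound 2 (beyond the scatter), a fall of comparable size is expected from compound 3 to compound 4, that is a step of about a number 37.8 percentage points lower from compound 3 to compound 4 (beyond the scatter). This rests on a single measured pair only, so the expected size carries considerable uncertainty. On this basis compound 4 is estimated to give about 42% in this assay, with a likely range from 25% to 60%.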

Compound 4, a percentage reported as inhibition, in the whole organism at one dose (the size of the read-out at that dose, not a potency): 74.3%
The estimate for compound 4 lay 32.3 percentage points below the measured number, and the stated range ends below it.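

In this assay, putting methyl in place of hydrogen on the amide-type nitrogen in a ring gives a step of a number 5.5 percentage points lower from compound 3 to compound 4 (within the scatter), so on this core the change has no effect that can be told apart from the ordinary spread of repeated measurements. The size of this change's effect therefore does not carry over from the core of compound 1 to the core of compound 3, and a large step seen on one core cannot be assumed on the other: the same change on two cores in this assay, a number 38.6 percentage points lower (beyond the scatter) from compound 1 to compound 2 and a number 5.5 percentage points lower (within the scatter) from compound 3 to compound 4, 33.1 percentage points apart, beyond the scatter of two such steps

Among the compounds shown here, with only two matched pairs, this does not show which feature of the two cores sets the steps apart, nor which step would be the more typical on a further core, and a reading at a single dose says nothing about potency.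

The compounds shown carry only hydrogen or methyl on that nitrogen, so it remains open how a longer chain such as ethyl, or a chain ending in an amine or a carboxylic acid, would read on either core. As far as these compounds go, it also remains open whether such groups would again give steps of different size on the two cores, or whether the two cores would then behave alike.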